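A few compounds are considered here, and "the series" means these few. Any claim that something is new, unique, unknown or untested is made for them only; others in the source may bear on it.

Measured compounds in the series:

Compound 1, `O=C(Nc1ccc(OC(F)(F)F)c(F)c1)NC1CCN(C(=O)C2(C(F)(F)F)CC2)CC1`, 5.94 in a physicochemical assay for lipophilicity, read by HPLC, with a stated time of 90 min, tested at 100 uM; on this read-out lower numbers stand for lower lipophilicity and higher numbers for higher lipophilicity.
Compound 2, `CC[C@H](C)C(=O)N1CCC(CC(=O)Nc2ccc(OC(F)(F)F)c(F)c2)CC1`, 7.68 in this assay.
Compound 3, `O=C(Nc1ccc(C(F)(F)F)c(F)c1)NC1CCN(C(=O)C2(C(F)(F)F)CC2)CC1`, 5.52 in this assay.

Compound 1 stands second highest of the three numbers. Its nearest neighbour is compound 3, reached by a number 0.42 log units lower from compound 1 to compound 3 (beyond the scatter), a trifluoromethyl in place of trifluoromethoxy on an aromatic carbon. Among the compounds with values here, compound 2 lies furthest away, and no single step connects it to compound 1; its value is simply the highest of the three.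

Compound 4, `O=C(Nc1ccc(OC(F)(F)F)c(F)c1)NC1CCN(C(=O)[C@@H]2CCOC2)CC1`, is not yet measured in this assay. It differs from compound 1 in one place: oxolan-3-yl in place of 1-(trifluoromethyl)cyclopropyl on a carbonyl carbon. Cut one bond further out, the change reads (1-(trifluoromethyl)cyclopropyl)carbonyl to (oxolan-3-yl)carbonyl. Within the data shown here, no measured step matches this change. Among the measured compounds shown here, the only step measured, from compound 1 to compound 3, swaps one fluorinated group for another on the aromatic ring and is of modest size. The change to compound 4 removes three fluorine atoms and a three-membered ring of carbon only, and brings in a five-membered ring with one hetero atom and one hydrogen-bond acceptor; on this read-out a drop beyond the scatter is expected, larger than the step from compound 1 to compound 3.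

For compound 4 the expected value in this assay is therefore 4.6, with a range of 3.9 to 5.3, which corresponds to an expected step of a number 1.34 log units lower from compound 1 to compound 4 (beyond the scatter).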

Compound 4, partition coefficient: 3.59
Estimate against measurement, compound 4: 1.01 log units above; measured number below the stated range.
By their numbers in this assay, from the lowest: compound 4; then compound 3; then compound 1; then compound 2.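

Oxolan-3-yl in place of 1-(trifluoromethyl)cyclopropyl, on a carbonyl carbon whose other neighbour is an amide-type nitrogen in a ring, gives in this assay the step of a number 2.35 log units lower from compound 1 to compound 4 (beyond the scatter) and so shows that this position can move the read-out by a large amount. That step stands against the modest a number 0.42 log units lower from compound 1 to compound 3 (beyond the scatter) on an aromatic carbon, and on these two steps alone, the group on the carbonyl carbon counts for more in this assay than the fluorinated group on the aromatic carbon. The change removes three fluorine atoms and a three-membered ring while bringing in a five-membered ring with a hydrogen-bond acceptor and a defined stereocentre, and nothing shown bears on which of these differences accounts for the step.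

Plain cyclopropyl on the same carbonyl carbon would separate the trifluoromethyl from the ring, and cyclopentyl would separate the ring oxygen from the ring size. Also open, on these data alone, are the other stereoisomer of oxolan-3-yl and whether the same change gives a step of similar size with trifluoromethyl in place of trifluoromethoxy on the aromatic carbon.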